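The compounds below may be only part of what the source reports. "The series", "measured", "known", "first", "only" and "open" are said of these compounds alone.

Two quinazolines carrying a sulfamoylphenyl group have been measured in a functional assay on A-431 cells (Homo sapiens) for antiproliferative activity, read by MTT assay, with a stated time of 72 h; a lower number here means a stronger inhibitor, a higher number a weaker inhibitor. Compound 1 `COc1cc2ncnc(Nc3cccc(Br)c3)c2cc1OCCCCC(=O)Nc1ccc(S(N)(=O)=O)cc1` gives 9750 nM. Compound 2 `NS(=O)(=O)c1ccc(NC(=S)Nc2ccc3ncnc(Nc4ccc(F)c(Cl)c4)c3c2)cc1` gives 37600 nM, the higher of the two numbers, and the gap from compound 1 lies beyond the scatter of repeated measurements.

Compound 3 `Cc1cccc(Nc2ncnc3ccc(NC(=S)Nc4ccc(S(N)(=O)=O)cc4)cc23)c1` differs from compound 2 only in 3-methylphenyl in place of 3-chloro-4-fluorophenyl on a nitrogen on an aromatic ring. Within the data shown here, no measured pair shows the effect of this change, so the size of a 1.3-fold higher number from compound 2 to compound 3 (0.12 log units; within the scatter) is expected to stay within the scatter, with a slight lean toward a higher number. Compound 3 is therefore estimated at 50000 nM, within 15000 nM to 150000 nM.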

Compound 3, half-maximal inhibitory concentration: 23800 nM
For compound 3 the middle estimate is 2.1-fold (0.32 log units) above the measured one, within the range that was stated.
By their numbers in this assay, from the lowest: compound 1; then compounds 3 and 2 (each within the scatter of the next).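

Among these compounds, on a nitrogen on an aromatic ring, 3-methylphenyl in place of 3-chloro-4-fluorophenyl gives a 1.6-fold lower number from compound 2 to compound 3 (0.20 log units; within the scatter) in this assay, the first direct reading of this change. At this position, on the core shared by these two compounds, the swap therefore does not separate them in this assay. No evidence bearing on this result is available.

Still open, on these data alone, is whether an unsubstituted phenyl or a longer alkyl chain on that nitrogen would give a step beyond the scatter. Also open, as far as these compounds go, is how a carboxylic acid in place of the sulfamoyl group would read.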